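Lipoic Amide Dithiols: Bromo for Chloro Expectation

The source may hold more compounds than are shown below. What is called first, only, known or untested is meant among the compounds shown, and "the series" means these compounds.

Two closed-ring amides open this set. Compound 1 `O=C(CCCCC1CCSS1)Nc1ccc(Cl)cn1` gives 0.76% in a functional assay on KB cells (Homo sapiens) for inhibition, read by MTT assay, with a stated time of 24 h, tested at 1 ug/mL (on this read-out lower numbers stand for less inhibition of growth and higher numbers for more inhibition of growth at the one concentration tested), and compound 2 `O=C(CCCCC1CCSS1)Nc1ccc(Br)cn1` gives 4.33% in the same assay. The step between them, a number 3.6 percentage points higher from compound 1 to compound 2 (within the scatter), belongs to the change (bromo in place of chloro on an aromatic carbon). Compound 3 `O=C(CCCCC(S)CCS)Nc1ccc(Cl)cn1` carries a different core, told by a group of 5 heavy atoms (3 carbon, 2 sulfur; no ring) in place of a group of 5 heavy atoms (3 carbon, 2 sulfur; one five-membered non-aromatic ring with 2 hetero atoms), on a saturated chain carbon, four bonds along the chain from a carbonyl carbon; in this assay compound 3 is reported as "not active" (no number reported). Compound 4 `O=C(CCCCC(S)CCS)Nc1ccc(Br)cn1` has not been measured. It differs from compound 3 by bromo in place of chloro on an aromatic carbon, the same change as that from compound 1 to compound 2, at a place described in the same words. Since that earlier step, a number 3.6 percentage points higher from compound 1 to compound 2 (within the scatter), stayed within the scatter, the author expects a step of similar small size here. For compound 4 the author therefore estimates 3%, with a range from 0% to 10%.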

Compound 4, percent growth inhibition at one concentration: 2.51%
The estimate for compound 4 lay 0.5 percentage points above the measured number, within the range that was stated.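

In this assay the new step is a number 1.8 percentage points lower from compound 2 to compound 4 (within the scatter) and so, with bromo on both, the open group of compound 4 and the closed ring of compound 2 cannot be told apart. This does not show that the bromo-for-chloro change carries from one core to the other: compound 3 is reported as "not active" (no number reported) and the step from it cannot be read, so a number 3.6 percentage points higher from compound 1 to compound 2 (within the scatter) has no readable counterpart on the open core. Nothing given here bears on the reason for these results.

The compounds shown leave open how a fluoro or an amine in the place of the bromo would read on either core. They also leave open what a longer chain between the carbonyl and the sulfur-bearing group would do.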